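A few compounds are considered here, and "the series" means these few. Any claim that something is new, unique, unknown or untested is made for them only; others in the source may bear on it.

Among the measured compounds shown here, compound 2, with the structure `COc1cc(CCCCC(O)CCc2ccc(O)c(OC)c2)ccc1O`, sits second highest of the three numbers known in an ADME assay on HT-22 cells (Mus musculus) for cytotoxicity, read by MTT assay, with a stated time of 24 h, tested at 10 uM (on this read-out lower numbers stand for a stronger effect and higher numbers for a weaker effect at the one concentration tested), where compound 2 gives 73%. Its nearest neighbour on this scale is compound 3, the structure `COc1cc(CCCCC(O)CCc2ccc(O)cc2)ccc1O`, which in this assay gives 74%; the two lie within the scatter of each other. Furthest from compound 2 stands compound 1, the structure `Oc1ccc(CCCCC(O)CCc2ccc(O)cc2)cc1`, which in this assay gives 43%.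

The step to compound 4, the structure `COc1cc(CCC(O)CCCCc2ccc(O)cc2)ccc1O`, removes one of the two methoxy groups of compound 2: hydrogen in place of methoxy on an aromatic carbon. For the measured compounds named here, two measured steps bear on this. The same kind of change, from compound 2 to the other single-methoxy compound, gave a number 1 percentage points higher from compound 2 to compound 3 (within the scatter). The opposite kind of change, adding a methoxy, gave a number 31 percentage points higher from compound 1 to compound 3 (beyond the scatter), a large shift. Compound 4 keeps one methoxy, so it matches compound 3 in the count of methoxy groups, and the step from compound 2 to compound 3 is the closer guide. Compound 4 is therefore expected to show a step of a number 3 percentage points lower from compound 2 to compound 4 (within the scatter), not beyond the scatter. The estimate for compound 4 in this assay is 70%, with a range from 55% to 85%.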

Compound 4, a percentage reported as activity, at one concentration (the size of the read-out at that concentration, not a potency): 75%
Compound 4: the middle estimate sits 5 percentage points below what was measured; low and high end bracket the measured number.
By their numbers in this assay, from the lowest: compound 1; then compounds 2, 3 and 4 (each within the scatter of the next).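

In this assay, the methoxy ortho to a hydroxy group now has a measured effect in both directions on the same ring: adding it to the core of compound 1 gives a number 32 percentage points higher from compound 1 to compound 4 (beyond the scatter), whereas removing it from the core of compound 2 by placing hydrogen there gives a number 2 percentage points higher from compound 2 to compound 4 (within the scatter). The large rise is therefore no feature of the methoxy in compound 3 alone, since a single methoxy on either ring goes with it among these compounds, while a second methoxy adds no step beyond the scatter. The size of the change depends on whether the other ring already carries a methoxy: the same change on two cores in this assay, a number 31 percentage points higher (beyond the scatter) from compound 1 to compound 3 and a number 2 percentage points lower (within the scatter) from compound 4 to compound 2, 33 percentage points apart, beyond the scatter of two such steps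

The compounds shown leave open whether this rise belongs to methoxy itself or would also come with another group at this place, such as ethoxy or a chlorine atom. They also leave open whether it would hold with a carbonyl in place of the chain hydroxy group or with a longer chain joining the two rings.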